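Inverting One Chain Stereocentre in Compound 1

A few compounds are considered here, and "the series" means these few. Any claim that something is new, unique, unknown or untested is made for them only; others in the source may bear on it.

Measured so far:
compound 1 `CCO[C@H](c1ccc(O[C@@H](CO)[C@@H](O)c2ccc(O)c(OC)c2)c(OC)c1)[C@H](CO)c1ccc(O)c(OC)c1`: 76300 nM
compound 2 `CCO[C@H](c1ccc(O[C@@H](CO)[C@@H](OC)c2ccc(O)c(OC)c2)c(OC)c1)[C@H](CO)c1ccc(O)c(OC)c1`: 80500 nM

In a functional assay on RAW264.7 cells (Mus musculus) for inhibition, read by Griess assay, with a stated time of 24 h (on this read-out higher numbers stand for weaker inhibition and lower numbers for stronger inhibition), compound 1 gives 76300 nM, and compound 2 gives 80500 nM; a 1.1-fold higher number from compound 1 to compound 2 (0.02 log units; within the scatter), so the two sit within the usual scatter of each other. Compound 3 `CCO[C@H](c1ccc(O[C@@H](CO)[C@@H](O)c2ccc(O)c(OC)c2)c(OC)c1)[C@@H](CO)c1ccc(O)c(OC)c1` is unmeasured. It differs from compound 1 in this way: the two compounds have the same atoms and bonds and differ only in configuration as drawn: 1 of 4 stereo elements differ; a stereocentre at a saturated chain carbon is drawn S in compound 1 and R in compound 3. Within the data shown here, no measured step involves such an inversion; the only measured step, a 1.1-fold higher number from compound 1 to compound 2 (0.02 log units; within the scatter), adds a methyl to an oxygen and is within the scatter, so it offers no guide. With nothing pointing either way, no step beyond the scatter is expected in this assay, a 1.0-fold lower number from compound 1 to compound 3 (0.00 log units; within the scatter). Compound 3 is therefore estimated at 76000 nM, between 30000 nM and 200000 nM.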

Compound 3, half-maximal inhibitory concentration: 66400 nM
Compound 3: the middle estimate sits 1.1-fold (0.06 log units) above what was measured, within the range that was stated.
By their numbers in this assay, from the lowest: compounds 3, 1 and 2 (each within the scatter of the next).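

Among these compounds, only one thing separates this pair: the fact that compounds 1 and 3 differ only in the configuration as drawn. In this assay, inverting the stereocentre at the saturated chain carbon from S to R gives a 1.1-fold lower number from compound 1 to compound 3 (0.06 log units; within the scatter). The configuration at this carbon therefore makes no readable difference here, something the earlier methyl step on an oxygen could not show. Going by these compounds, what inverting any of the other three stereo elements would do stays open. So does the effect of an amine or a carboxylic acid on the core of compound 1.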